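Swapping the Aromatic Ring on the Hydrazone Arm

A few compounds are considered here, and "the series" means these few. Any claim that something is new, unique, unknown or untested is made for them only; others in the source may bear on it.

Measured compounds:
Compound 1, `CN(C)CCn1cnnc1-c1cc(Oc2ccc(NC(=O)N/N=C/c3c[nH]c4ccccc34)cc2F)ccn1`, gives 1630 nM in a functional assay on NCI-H460 cells (Homo sapiens) for cytotoxicity, read by MTT assay, with a stated time of 72 h; a lower number here means a stronger inhibitor, a higher number a weaker inhibitor.
Compound 2, `CN(C)CCn1cnnc1-c1cc(Oc2ccc(NC(=O)N/N=C/c3ccccc3)cc2F)ccn1`, gives 1780 nM in this assay.

Two compounds share the same core and differ only in the ring attached to the carbon that carries a double bond to nitrogen. Compound 2, with a plain phenyl there, cannot be told apart from compound 1: the step of a 1.1-fold higher number from compound 1 to compound 2 (0.04 log units; within the scatter) lies within the scatter of repeated measurements, so the two numbers are, for practical purposes, the same.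

Compound 3, `CN(C)CCn1cnnc1-c1cc(Oc2ccc(NC(=O)N/N=C/c3ccc(O)c(O)c3)cc2F)ccn1`, takes the next step along this arm. Its change from compound 2 is 3,4-dihydroxyphenyl in place of phenyl on a carbon with a double bond to nitrogen. For the measured compounds named here, the only measured step that bears on this, from compound 1 to compound 2, exchanged one aromatic ring for another at the same carbon and produced no change beyond the scatter. Going by the values given here, no measured step adds hydroxyl groups to this ring, so the bearing is indirect. On that basis compound 3 is expected to sit close to compound 2, with a step of a 1.0-fold higher number from compound 2 to compound 3 (0.00 log units; within the scatter). The estimate for compound 3 in this assay is 1800 nM, within a range from 700 nM to 4500 nM.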

Compound 3, half-maximal inhibitory concentration: 1930 nM
For compound 3 the middle estimate is 1.1-fold (0.03 log units) below the measured one; the range from low to high includes it.
By their numbers in this assay, from the lowest: compounds 1, 2 and 3 (each within the scatter of the next).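

Compound 3 is the first of these compounds to carry hydroxyl groups on this ring, so the 3,4-dihydroxyphenyl group brings hydrogen-bond donors and acceptors that phenyl does not have, yet this assay shows a 1.1-fold higher number from compound 2 to compound 3 (0.04 log units; within the scatter) for this change. The comparison with the indole compound reads the same, at a 1.2-fold higher number from compound 1 to compound 3 (0.07 log units; within the scatter), so 1H-indol-3-yl, phenyl and 3,4-dihydroxyphenyl on the carbon with a double bond to nitrogen give numbers that cannot be told apart across these three compounds, even though the change now adds hydrogen-bond donors and not just a different aromatic ring. Nothing available explains why these changes leave the number in place.

The compounds shown all keep an aromatic ring at this carbon, so it remains open whether a non-aromatic group such as a cyclohexyl ring or a short alkyl chain would give a similar number. As far as these compounds go, it is equally open whether a ring bearing an amine, a carboxylic acid or a nitrile would stay within the same narrow band in this assay or finally move the result.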